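A Ketone Chain Lengthened on a Second Core

The compounds below may be only part of what the source reports. "The series", "measured", "known", "first", "only" and "open" are said of these compounds alone.

Compound 1 `CCCn1c(=O)n(CC(C)=O)c(=O)c2[nH]cnc21` and compound 2 `CCCn1c(=O)n(CCC(C)=O)c(=O)c2[nH]cnc21` share one core, while compound 3 `CCCn1c(=O)n(C)c(=O)c2c1ncn2CC(C)=O` and compound 4 `CCCn1c(=O)n(C)c(=O)c2c1ncn2CCC(C)=O` share another, and the difference between the two cores is not broken down here. In a functional assay (trachea) with Cavia porcellus as the target (a lower number here means that less compound is needed, a higher number that more compound is needed for the effect), compound 1 gives 14900 nM. Compound 2 carries the change (2-oxopropyl in place of acetyl on a saturated chain carbon bound to an aromatic nitrogen), and in this assay compound 2 gives 3500 nM. Going by the values given here, the resulting step is a 4.3-fold lower number from compound 1 to compound 2 (0.63 log units; beyond the scatter), the only measured instance of this change among the four compounds.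

On the other core, compound 3 gives 1900 nM in this assay. Its number stands within the scatter of compound 2 and beyond the scatter of compound 1, so nothing can be said about an order between compound 3 and compound 2.

Compound 4 differs from compound 3 by 2-oxopropyl in place of acetyl on a saturated chain carbon bound to an aromatic nitrogen, the same change as that from compound 1 to compound 2, at the same kind of place. Whether the change carries over to the second core is not known from these three compounds. An improvement in the same direction is expected because a 4.3-fold lower number from compound 1 to compound 2 (0.63 log units; beyond the scatter) was seen on the first core, yet a somewhat smaller step is expected, namely a 2.4-fold lower number from compound 3 to compound 4 (0.38 log units; beyond the scatter), since the ketone chain sits on a different core here. Compound 4 is therefore estimated at 800 nM in this assay, with a likely range from 300 nM to 2500 nM.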

Compound 4, half-maximal effective concentration: 12200 nM
Beside the measured number, compound 4's estimate is 15-fold (1.18 log units) below it; measured number above the stated range.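

On the second core the change runs the opposite way in this assay: the step is a 6.4-fold higher number from compound 3 to compound 4 (0.81 log units; beyond the scatter). Set beside the first core, the same replacement of acetyl by 2-oxopropyl, on a saturated chain carbon bound to an aromatic nitrogen, does not carry over in direction, and the two steps differ by more than the scatter of such steps: the same change on two cores in this assay, a 4.3-fold lower number (0.63 log units; beyond the scatter) from compound 1 to compound 2 and a 6.4-fold higher number (0.81 log units; beyond the scatter) from compound 3 to compound 4, 27-fold (1.44 log units) apart, beyond the scatter of two such steps. This shows that, for these four compounds, the step measured on one core gave no reliable guide to the step on the other, but it rests on a single pair per core and does not show what produces the reversal or how the change would behave on any further core.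

The compounds shown leave open whether a longer chain ending in the same ketone would continue the fall in the number seen on the core of compound 1 or the rise seen on the core of compound 3, and whether an alcohol or an amine in place of the ketone would split the two cores in the same way. The difference between the two cores is also not broken down by these compounds, so which part of it goes with the reversal remains unresolved.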